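The source may hold more compounds than are shown below. What is called first, only, known or untested is meant among the compounds shown, and "the series" means these compounds.

Compound 1 `CC(C(=O)N1CCN(c2ccccc2)CC1)N1C(=O)CCC1=O` and compound 2 `CC(C(=O)N1CCN(c2ccccc2F)CC1)N1C(=O)CCC1=O` share one core. In a functional assay on the whole organism (strain Swiss) with Mus musculus as the target, in the maximal electroshock model, with a stated time of 0.25 h, at a dose of 300 mg/kg by the intraperitoneal route (on this read-out lower numbers stand for a weaker effect and higher numbers for a stronger effect at the one dose given), compound 1 gives 100%, and compound 2 gives 100%. The step of no change at the digits printed from compound 1 to compound 2 (within the scatter) lies within the scatter, so compound 2 stands level with compound 1 on the numbers shown. Compound 3 `CC(C(=O)N1CCN(c2ccccc2C(F)(F)F)CC1)N1C(=O)CCC1=O` carries the change (trifluoromethyl in place of fluoro on an aromatic carbon). Among the measured compounds shown here, only that one earlier step bears on this change, and it showed no movement beyond the scatter. For compound 3 the expected step is therefore no change at the digits printed from compound 2 to compound 3 (within the scatter), none beyond the scatter. Compound 3 is thus expected to give 100%, within a range from 75% to 100%.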

Compound 3, a percentage reported as activity, at one dose (the size of the read-out at that dose, not a potency): 100%
Beside the measured number, compound 3's estimate shows no gap at the digits printed; low and high end bracket the measured number.
By their numbers in this assay, from the lowest: compounds 1, 2 and 3 (each within the scatter of the next).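

In this assay, trifluoromethyl in place of fluoro on an aromatic carbon, ortho to a large group, gives no change at the digits printed from compound 2 to compound 3 (within the scatter), so this place has now taken a second substituent without a shift in the read-out. Against hydrogen at the same place, trifluoromethyl gives no change at the digits printed from compound 1 to compound 3 (within the scatter). No evidence on the cause of this result is available.

Going by these compounds, whether an amine or a carboxylic acid at this place would move the read-out stays open. So does whether these three compounds would separate at a lower dose.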